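Swapping the amide-side aryl group of a cytotoxic triazine thioether

The compounds below may be only part of what the source reports. "The series", "measured", "known", "first", "only" and "open" are said of these compounds alone.

Of the compounds shown here, three of a shared core have been measured in an ADME assay on MT4 cells (Homo sapiens) for cytotoxicity, read by MTT assay; on this read-out higher numbers stand for lower toxicity in this test and lower numbers for higher toxicity in this test. Compound 2 `O=C(CSc1nncnc1-c1ccccc1Cl)Nc1ccc(Cl)cc1Cl` gives 51000 nM in this assay. Compound 1 `Cc1ccc(NC(=O)CSc2nncnc2-c2cccc3ccccc23)c(Br)c1` gives 166000 nM, and compound 3 `O=C(CSc1nncnc1-c1cccc2ccccc12)Nc1ccc(Cl)cc1Cl` gives 254000 nM. Among these three numbers compound 2 stands lowest, with a gap to compound 1 and a larger gap to compound 3, both beyond the scatter, so compound 2 is the most cytotoxic of the three in this assay.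

Compound 4 `O=C(CSc1nncnc1-c1ccccc1Cl)Nc1ccccc1Br` is not yet measured. It differs from compound 2 in one place: 2-bromophenyl in place of 2,4-dichlorophenyl on an amide-type nitrogen.

Among the measured compounds shown here, one measured step bears on such a change of the aryl group on the amide-type nitrogen. From compound 1 to compound 3 the change was 2,4-dichlorophenyl in place of 2-bromo-4-methylphenyl, and this assay gave a 1.5-fold higher number from compound 1 to compound 3 (0.18 log units; within the scatter). That step lay within the scatter, so a change of this kind on the same nitrogen has so far moved the number little. The expected step from compound 2 to compound 4 in this assay is therefore a 1.3-fold higher number from compound 2 to compound 4 (0.11 log units; within the scatter), with no direction expected beyond the scatter. Compound 4 is estimated to give 65000 nM in this assay, with a range from 25000 nM to 170000 nM.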

Compound 4, half-maximal cytotoxic concentration: 73000 nM
Estimate against measurement, compound 4: 1.1-fold (0.05 log units) below, and the stated range covers the measured number.
By their numbers in this assay, from the lowest: compounds 2 and 4 (each within the scatter of the next); then compounds 1 and 3 (each within the scatter of the next).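

In this assay, the new swap gives a 1.4-fold higher number from compound 2 to compound 4 (0.16 log units; within the scatter), so the low number of compound 2 in this test does not depend on keeping 2,4-dichlorophenyl on the amide-type nitrogen, since 2-bromophenyl serves about as well there. The earlier step, a 1.5-fold higher number from compound 1 to compound 3 (0.18 log units; within the scatter), came from a different remainder of the molecule, so two aryl swaps at this nitrogen, each within the scatter, now stand on two different parents, and the finding no longer rests on a single pair. No evidence is available on why this nitrogen tolerates these swaps with so little movement in the number.

The compounds shown carry only halogen-bearing phenyl groups on this nitrogen, one of them with a methyl group as well, so it remains open whether the number would hold with an amine or a carboxylic acid on that phenyl ring, or with a longer alkyl chain in place of the ring. On these data alone, it also remains open whether 2-bromophenyl would behave the same way on the core of compound 3.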